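Series notes: the step from compound 3 to compound 4

The compounds below may be only part of what the source reports. "The series", "measured", "known", "first", "only" and "open" are said of these compounds alone.

Measured so far:
compound 1, `COC(=O)c1ccc(Br)c(CSc2nc3ccccc3n2CC(=O)O)c1`, 45 nM
compound 2, `COc1ccc(C(=O)c2ccccc2)cc1CSc1nc2cc(F)ccc2n1CC(=O)O`, 1.7 nM
compound 3, `COc1ccc(C(=O)NCc2ccccc2)cc1CSc1nc2cc(F)ccc2n1CC(=O)O`, 59 nM

In an assay on HEK293 cells for displacement of a labelled ligand from prostaglandin D2 receptor 2 (Homo sapiens) (on this read-out lower numbers stand for stronger inhibition and higher numbers for weaker inhibition), compound 3 gives the highest number of the three; compound 1 lies within the scatter of it. Among the measured compounds shown here, the only large step on record is a 35-fold higher number from compound 2 to compound 3 (1.54 log units; beyond the scatter), an exchange of the whole group on the carbonyl carbon. Compound 4, `CCN(Cc1ccccc1)C(=O)c1ccc(OC)c(CSc2nc3cc(F)ccc3n2CC(=O)O)c1`, differs from compound 3 only by ethyl in place of hydrogen on an amide-type nitrogen. For the measured compounds named here, no measured step touches the amide nitrogen, and the carbonyl-group exchange is a different kind of change, so it offers no direct precedent. The step of a 2.4-fold lower number from compound 3 to compound 4 (0.37 log units; beyond the scatter) is therefore expected to be modest, leaning towards a lower number but possibly within the scatter. Compound 4 is estimated at 25 nM, with a range of 6 nM to 100 nM.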

Compound 4, half-maximal inhibitory concentration: 495 nM
Compound 4: the middle estimate sits 20-fold (1.30 log units) below what was measured; the measured number lies above the stated range.
By their numbers in this assay, from the lowest: compound 2; then compounds 1 and 3 (each within the scatter of the next); then compound 4.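

Replacing the amide hydrogen with ethyl is the first change at this nitrogen among the compounds shown, and it gives an 8.4-fold higher number from compound 3 to compound 4 (0.92 log units; beyond the scatter) in the direction of weaker inhibition, so this position does not tolerate the added ethyl without loss. With the whole group on the carbonyl carbon exchanged, the series shows a 290-fold higher number from compound 2 to compound 4 (2.46 log units; beyond the scatter) and thus extends the loss already seen with benzylamino. No evidence on the origin of this loss is available.

Open, from the compounds shown here alone, is how methyl or a longer chain on this nitrogen would compare with ethyl. Also open, going by these compounds, is whether a cyclic amine in place of benzyl(ethyl)amino would follow the same trend.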